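Sulfanyl substituent variation and cytotoxicity in one series

The source may report more compounds than this note shows. Statements on the series, on what has been measured and on what is new or still open speak of the compounds shown alone.

Compound 3 `CCCSc1nnc(-c2cc([N+](=O)[O-])cc([N+](=O)[O-])c2)n1Cc1ccccc1` stands at the limit of an ADME assay on A-431 cells (Homo sapiens) for cytotoxicity, with a stated time of 48 h; on this read-out lower numbers stand for stronger inhibition and higher numbers for weaker inhibition: compound 3 gives > 30000 nM, a limit rather than a number. Compound 2 `CSc1nnc(-c2cc([N+](=O)[O-])cc([N+](=O)[O-])c2)n1Cc1ccccc1` likewise gives a limit, > 30000 nM. Compound 1 `Cn1c(SCc2ccc(Cl)c(Cl)c2)nnc1-c1cc([N+](=O)[O-])cc([N+](=O)[O-])c1` gives a limit as well, > 30000 nM. Within the data shown here, the only step between measured neighbours reads a step that the two limits leave unreadable from compound 2 to compound 3, and the limit of > 30000 nM in this assay, at which 3 of the 3 values shown sit, holds every value shown. Compound 4 `O=[N+]([O-])c1cc(-c2nnc(SCc3ccc(Cl)c(Cl)c3)n2Cc2ccccc2)cc([N+](=O)[O-])c1` differs from compound 3 by 3,4-dichlorophenyl in place of ethyl on a saturated chain carbon bound to a sulfur. Among the measured compounds shown here, no measured step bears on this change; compound 1 carries the same (3,4-dichlorobenzyl)sulfanyl group and sits at the limit. The step from compound 3 to compound 4 is expected to read a step that the limit leaves unreadable from compound 3 to compound 4. Compound 4 is estimated at 45000 nM, with a range from 15000 nM to 150000 nM, most likely again only a limit.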

Compound 4, half-maximal inhibitory concentration: > 30000 nM
Compound 4 ended at the assay's limit; the forecaster's own chance of this, stated with the estimate: 85%; the middle value does not contradict the limit.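

Among these compounds, no step from compound 1, compound 2 or compound 3 to compound 4 can be read, because all four values are limits: the limit of > 30000 nM in this assay, at which 4 of the 4 values shown sit. The compounds shown leave open whether any change on the shared core brings a measurable value.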